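A few compounds are considered here, and "the series" means these few. Any claim that something is new, unique, unknown or untested is made for them only; others in the source may bear on it.

The measured compounds, each read in an ADME assay on Vero cells (Chlorocebus sabaeus) for cytotoxicity, read by MTT assay, with a stated time of 72 h; a lower number here means a stronger inhibitor, a higher number a weaker inhibitor:
Compound 1 `O=C(NNC(=O)c1cc([N+](=O)[O-])c[nH]1)Nc1ccc([N+](=O)[O-])cc1` gives 211000 nM.
Compound 2 `Cn1cc([N+](=O)[O-])cc1C(=O)NNC(=O)Nc1ccc([N+](=O)[O-])cc1` gives 402000 nM.
Compound 3 `COc1cc(NC(=S)NNC(=O)c2cc([N+](=O)[O-])cn2C)cc(OC)c1OC` gives 392000 nM.

Compound 2 and compound 1 differ in a single place, (hydrogen in place of methyl on an aromatic nitrogen). That change gave a step of a 1.9-fold lower number from compound 2 to compound 1 (0.28 log units; within the scatter) in this assay. Compound 3 carries a different core from compound 2; how the two cores differ is not broken down here. What its value does show is that compound 3 and compound 2 lie within the scatter of each other, and the same holds for compound 3 and compound 1. Among these three measured compounds, then, no one stands apart from the others in this assay.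

Compound 4 `COc1cc(NC(=S)NNC(=O)c2cc([N+](=O)[O-])c[nH]2)cc(OC)c1OC` has not yet been measured in this assay. Among the measured compounds shown here, it is related to compound 3 by hydrogen in place of methyl on an aromatic nitrogen, which is the same change as the one from compound 2 to compound 1, made at the same place. Because the earlier step came to a 1.9-fold lower number from compound 2 to compound 1 (0.28 log units; within the scatter), compound 4 is expected to show a step of a 1.7-fold lower number from compound 3 to compound 4 (0.23 log units; within the scatter) from compound 3, a movement that would stay within the scatter. On that basis, compound 4 is estimated at 230000 nM, with the expected range running from 110000 nM to 500000 nM.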

Compound 4, half-maximal inhibitory concentration: 328000 nM
Compound 4: middle estimate off by 1.4-fold (0.15 log units), on the low side, within the range that was stated.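

Carried onto the core of compound 3, hydrogen in place of methyl on an aromatic nitrogen gave a 1.2-fold lower number from compound 3 to compound 4 (0.08 log units; within the scatter) in this assay. Set beside the earlier step on the core of compound 1, the new step shows no difference that can be told from the scatter: the same change on two cores in this assay, a 1.9-fold lower number (0.28 log units; within the scatter) from compound 2 to compound 1 and a 1.2-fold lower number (0.08 log units; within the scatter) from compound 3 to compound 4, 1.6-fold (0.20 log units) apart, within the scatter of two such steps. The change therefore carried over between these two cores without a detectable difference in its step, but neither step stands clear of the scatter, so the pair does not show that the change moves the number at all, and two cores give no basis for a rule across the whole series.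

The compounds shown leave open whether a different group on that aromatic nitrogen, such as an ethyl group or a longer chain, would bring a step beyond the scatter in this assay. They also leave open what an amine or a carboxylic acid in place of the nitro group would do, and whether the step between methyl and hydrogen on the nitrogen would stay the same on such a compound.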